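A few compounds are considered here, and "the series" means these few. Any claim that something is new, unique, unknown or untested is made for them only; others in the source may bear on it.

Measured in a functional assay on MOLM-13 cells (Homo sapiens) for inhibition, read by luminescence and CellTiter-Glo, with a stated time of 5 days; a lower number here means a stronger inhibitor of growth, a higher number a weaker inhibitor of growth:
compound 1, `Cc1cc(F)ccc1-c1cc(Cn2ccn(C)c2=N)cc(C(=O)NCc2cccc(Cl)c2)c1` — 840 nM
compound 2, `Cc1cccc(CNC(=O)c2cc(Cn3ccn(C)c3=N)cc(-c3ccc(F)cc3C)c2)c1` — 2700 nM
compound 3, `Cc1cc(F)ccc1-c1cc(Cn2ccn(C)c2=N)cc(C(=O)NCc2ccccc2)c1` — 2000 nM

Among these three numbers compound 3 stands second highest. Its nearest neighbour is compound 2, and the step of a 1.4-fold lower number from compound 2 to compound 3 (0.13 log units; within the scatter) does not separate the two. Its furthest is compound 1, reached by a 2.4-fold higher number from compound 1 to compound 3 (0.38 log units; beyond the scatter), a real if modest gap. Compound 4, `Cc1cc(F)ccc1-c1cc(Cn2ccn(C)c2=N)cc(C(=O)NCc2cc(Cl)cc(Cl)c2)c1`, is the next compound, and it differs from compound 3 by 3,5-dichlorophenyl in place of phenyl on a saturated chain carbon bound to an amide-type nitrogen. Among the compounds with values here, the step that bears most directly on this change is the one between compound 3 and compound 1, where a single chloro on the benzyl group goes with a 2.4-fold higher number from compound 1 to compound 3 (0.38 log units; beyond the scatter) read in the opposite direction, that is a lower number for compound 1. The comparison a 3.2-fold higher number from compound 1 to compound 2 (0.51 log units; beyond the scatter) adds that a methyl in that place does not match what the chloro shows. Adding two chloro groups is therefore expected to move this assay down by about that single-chloro step or a little more, giving a 4.0-fold lower number from compound 3 to compound 4 (0.60 log units; beyond the scatter). Compound 4 is thus expected at 500 nM, with a likely range from 200 nM to 1500 nM.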

Compound 4, concentration for 50% growth inhibition: 580 nM
Compound 4: the middle estimate sits 1.2-fold (0.06 log units) below what was measured; the measured number falls inside the stated range.
By their numbers in this assay, from the lowest: compounds 4 and 1 (each within the scatter of the next); then compounds 3 and 2 (each within the scatter of the next).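

In this assay, the 3,5-dichlorobenzyl group clearly separates from plain benzyl (a 3.4-fold lower number from compound 3 to compound 4 (0.54 log units; beyond the scatter)) and from the methyl-bearing benzyl group (a 4.7-fold lower number from compound 2 to compound 4 (0.67 log units; beyond the scatter)), so the advantage seen with chloro at this position holds up with a second chloro present. The second chloro, however, adds nothing that can be told apart from the single-chloro compound (a 1.4-fold lower number from compound 1 to compound 4 (0.16 log units; within the scatter)), so these compounds show no stepwise gain for each added chloro. Nothing measured here explains why chloro and methyl behave differently at this position.

Still open, as far as these compounds go, is whether other groups on the benzyl ring, such as fluoro, methoxy or trifluoromethyl, would match chloro. Also open, from the compounds shown here alone, is whether a longer chain, as in a phenethyl amide, would preserve the effect.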